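Ethyl for cyclohexyl on an aromatic nitrogen: cytotoxicity note

This account rests on a few compounds, and the source may have more. Where it says the series, first, only, none or still open, it means among the compounds named here.

compound 1 `COC(=O)c1cc2c(Nc3ccc(OC(F)(F)F)cc3)ncnc2s1`: in an ADME assay on BaF3 cells (Mus musculus) for cytotoxicity (on this read-out lower numbers stand for an effect already at smaller amounts and higher numbers for an effect only at larger amounts of compound), compound 1 sits at a limit, > 10000 nM
compound 2 `FC(F)(F)Oc1ccc(Nc2ncnc3nn(C4CCCCC4)cc23)cc1`: in this assay compound 2 sits at a limit, > 10000 nM
compound 3 `CC(C)(C)n1ncc2c(Nc3ccc(OC(F)(F)F)cc3)ncnc21`: in this assay compound 3 gives 7300 nM

Among the compounds with values here, compound 2 stands only as a limit in this assay; it shares the limit of > 10000 nM in this assay, at which 2 of the 3 values shown sit, with compound 1, and compound 3 is the one value with a number. Within the data shown here, no measured pair differs in a single place, so no step of this kind has been quantified. Compound 4 `CCn1cc2c(Nc3ccc(OC(F)(F)F)cc3)ncnc2n1` differs from compound 2 by ethyl in place of cyclohexyl on an aromatic nitrogen. In this assay the step from this change is expected to stay within the scatter, a step that the limit leaves unreadable from compound 2 to compound 4. Compound 4 is therefore estimated at 12000 nM, with a range from 5000 nM to 30000 nM, and the assay may well again report only a limit.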

Compound 4, half-maximal effective concentration: > 10000 nM
Compound 4: no number, only a limit; the forecaster's own chance of this, stated with the estimate: 65%; the middle value lies beyond the limit too.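

Compound 2 and compound 4 both stand only as limits in this assay, so no step between them can be read, and both share one limit: the limit of > 10000 nM in this assay, at which 3 of the 4 values shown sit.

The compounds shown leave open whether ethyl and cyclohexyl on an aromatic nitrogen differ at all in this assay.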